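This account rests on a few compounds, and the source may have more. Where it says the series, first, only, none or still open, it means among the compounds named here.

Compound 2 `COc1ccc(N(CC(=O)NCCCSc2ccccc2)C(=O)CNC(=O)OC(C)(C)C)cc1` and compound 1 `COc1ccc(N(CC(=O)NCCC[Se]c2ccccc2)C(=O)c2ccccc2)cc1` share a core and sit on the same limit in an ADME assay on cells (Fibroblast, Homo sapiens) for cytotoxicity, read by MTT assay, with a stated time of 24 h; a higher number here means a weaker inhibitor, a lower number a stronger inhibitor. In this assay compound 2 gives >= 100000 nM, a limit of the assay and not a number. In this assay compound 1 gives >= 100000 nM, likewise a limit. For the measured compounds named here, compound 2 therefore stands on (the limit of >= 100000 nM in this assay, at which 2 of the 2 values shown sit); no compound here gives a number. Compound 3 `COc1ccc(N(CC(=O)NCCCSc2ccccc2)C(=O)c2ccccc2)cc1` differs from compound 2 by phenyl in place of ((tert-butoxycarbonyl)amino)methyl on a carbonyl carbon. With nothing but limits shown, no step beyond the scatter is expected in this assay. Compound 3 is expected at 100000 nM, between 50000 nM and 200000 nM. The expected step from compound 2 to compound 3 is a number no higher from compound 2 to compound 3 (the limit leaves the size open), most likely again a limit.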

Compound 3, half-maximal inhibitory concentration: >= 100000 nM
Compound 3: no number, only a limit (the forecaster's own chance of this, stated with the estimate: 85%); the middle value lies on the limit itself.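

In this assay the steps from compound 2 and from compound 1 to compound 3 cannot be read, as all three compounds stand on one limit: the limit of >= 100000 nM in this assay, at which 3 of the 3 values shown sit. Going by these compounds, whether any real difference in cytotoxicity separates these compounds stays open.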